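Para-substituent removal on the anilino ring of compound 3

The source may hold more compounds than are shown below. What is called first, only, known or untested is meant among the compounds shown, and "the series" means these compounds.

Measured compounds:
compound 1 `COc1cc2ncnc(Nc3ccc(Cl)cc3)c2cc1OCCCCC(=O)Nc1ccc(S(N)(=O)=O)cc1`: 7120 nM
compound 2 `COc1cc2ncnc(Nc3ccc(C(F)(F)F)cc3)c2cc1OCCCCC(=O)Nc1ccc(S(N)(=O)=O)cc1`: 16900 nM
compound 3 `COc1cc2ncnc(Nc3ccc(C)cc3)c2cc1OCCCCC(=O)Nc1ccc(S(N)(=O)=O)cc1`: 35500 nM

All three share a core and differ only in the group on the anilino ring. In a functional assay on A-431 cells (Homo sapiens) for antiproliferative activity, read by MTT assay, with a stated time of 72 h (a lower number here means a stronger inhibitor, a higher number a weaker inhibitor), compound 1 gives the lowest number of the three, compound 2 sits in the middle, and compound 3 gives the highest. The steps are all beyond the scatter but modest: a 2.4-fold higher number from compound 1 to compound 2 (0.38 log units; beyond the scatter), a 5.0-fold higher number from compound 1 to compound 3 (0.70 log units; beyond the scatter) and a 2.1-fold higher number from compound 2 to compound 3 (0.32 log units; beyond the scatter).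

Compound 4 `COc1cc2ncnc(Nc3ccccc3)c2cc1OCCCCC(=O)Nc1ccc(S(N)(=O)=O)cc1` has not yet been measured in this assay. Its change from compound 3 is hydrogen in place of methyl on an aromatic carbon. For the measured compounds named here, none of the measured steps removes the group outright; each swaps one group for another, so they bear on the step only indirectly. They show that the three groups tried so far spread the numbers over a modest range, with chloro giving the lowest and methyl the highest.

With nothing measured for the bare ring, compound 4 is expected to land near compound 3, with a step of a 1.3-fold higher number from compound 3 to compound 4 (0.10 log units; within the scatter). The estimate for compound 4 is therefore 45000 nM, expected to fall between 15000 nM and 130000 nM.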

Compound 4, half-maximal inhibitory concentration: 25200 nM
Estimate against measurement, compound 4: 1.8-fold (0.25 log units) above; low and high end bracket the measured number.
By their numbers in this assay, from the lowest: compound 1; then compounds 2, 4 and 3 (each within the scatter of the next, the first and the last beyond it).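

In this assay, removing the methyl group leaves the number within the scatter, with a 1.4-fold lower number from compound 3 to compound 4 (0.15 log units; within the scatter), and compound 4 is likewise not separated from the trifluoromethyl compound, with a 1.5-fold higher number from compound 2 to compound 4 (0.17 log units; within the scatter). So the bare phenyl ring cannot be told apart from either of these two substituted rings, even though those two are separated from each other, and of the three groups only chloro stands clearly apart from hydrogen at this place, with a 3.5-fold higher number from compound 1 to compound 4 (0.55 log units; beyond the scatter). Nothing available here explains why chloro separates from hydrogen while methyl and trifluoromethyl do not.

The compounds shown leave open whether this lower number is particular to chloro or is shared by other groups at this place on the anilino ring, such as fluoro, bromo, methoxy or an amine. They also leave open whether chloro would keep its separation from hydrogen with a longer chain between the shared core and the amide.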